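Ester Chain Replaces Carbamoyl on the Amine of Compound 1

This account rests on a few compounds, and the source may have more. Where it says the series, first, only, none or still open, it means among the compounds named here.

Compound 1 `Cc1cn([C@@H]2O[C@H](CO[Si](C)(C)C(C)(C)C)[C@@]3(OS(=O)(=O)C=C3NCC(N)=O)[C@H]2O[Si](C)(C)C(C)(C)C)c(=O)n(C)c1=O` is the least toxic of the three measured compounds: in a functional assay on CCRF-CEM cells (Homo sapiens) (on this read-out higher numbers stand for lower toxicity in this test and lower numbers for higher toxicity in this test), compound 1 gives 14600 nM. Compound 2 `C=C(C)C(=O)NC(=O)NC1=CS(=O)(=O)O[C@@]12[C@@H](CO[Si](C)(C)C(C)(C)C)O[C@@H](n1cc(C)c(=O)n(C)c1=O)[C@@H]2O[Si](C)(C)C(C)(C)C` gives 1200 nM and compound 3 `Cc1cn([C@@H]2O[C@H](CO[Si](C)(C)C(C)(C)C)[C@@]3(OS(=O)(=O)C=C3NC(=O)NC(=O)c3ccccc3)[C@H]2O[Si](C)(C)C(C)(C)C)c(=O)n(C)c1=O` gives 2290 nM. Both measured steps away from compound 1 lower the number: a 12-fold lower number from compound 1 to compound 2 (1.09 log units; beyond the scatter) and a 6.4-fold lower number from compound 1 to compound 3 (0.80 log units; beyond the scatter). Between those two, a 1.9-fold higher number from compound 2 to compound 3 (0.28 log units; within the scatter). Compound 4 `COC(=O)CCNC1=CS(=O)(=O)O[C@@]12[C@@H](CO[Si](C)(C)C(C)(C)C)O[C@@H](n1cc(C)c(=O)n(C)c1=O)[C@@H]2O[Si](C)(C)C(C)(C)C` differs from compound 1 in one place: (methoxycarbonyl)methyl in place of carbamoyl on a saturated chain carbon bound to an amine nitrogen. The two measured steps from compound 1 both exchanged carbamoylmethyl for acylcarbamoyl groups on the amine nitrogen, whereas compound 4 keeps a saturated chain there, so they bear on it only loosely. A smaller downward shift is therefore expected, a 1.8-fold lower number from compound 1 to compound 4 (0.26 log units; within the scatter). Compound 4 is estimated at 8000 nM, with a range of 3000 nM to 25000 nM.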

Compound 4, half-maximal cytotoxic concentration: > 250000 nM
Compound 4 gave a limit, no number (the forecaster's own chance of this, stated with the estimate: 10%); middle value at least 31-fold (1.49 log units) away from the limit.
By their numbers in this assay, from the lowest: compounds 2 and 3 (each within the scatter of the next); then compound 1. At a limit, above all of these: compound 4.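

Compound 4 stands at > 250000 nM in this assay, a limit of the assay and not a number. Exchanging carbamoyl for (methoxycarbonyl)methyl on a saturated chain carbon bound to an amine nitrogen gives an at least 17-fold higher number from compound 1 to compound 4 (1.23 log units; beyond the scatter) and so runs opposite to both earlier steps from compound 1. For the compounds shown here, the gap to the acylcarbamoyl compounds is wider still, with an at least 100-fold higher number from compound 3 to compound 4 (2.03 log units; beyond the scatter) and an at least 200-fold higher number from compound 2 to compound 4 (2.31 log units; beyond the scatter), so changes on this amine nitrogen span a far broader range than the earlier compounds showed.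

The compounds shown do not separate the effect of the methyl ester from that of the longer chain. On these data alone, whether a carboxylic acid or a primary amide on that longer chain would give a similarly high number remains open.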